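From Iodo to Methoxy in a Growth Inhibition Series

A few compounds are considered here, and "the series" means these few. Any claim that something is new, unique, unknown or untested is made for them only; others in the source may bear on it.

In a functional assay on Hs-578T cells (Homo sapiens) for inhibition (a higher number here means a weaker inhibitor of growth, a lower number a stronger inhibitor of growth), compound 1 `NC(=O)c1cc(Cl)ccc1NC(=O)COc1ccccc1` gives 4650 nM and compound 2 `NC(=O)c1cc(I)ccc1NC(=O)COc1ccccc1` gives 630 nM, the lower of the two numbers. Compound 3 `COc1ccc(NC(=O)COc2ccccc2)c(C(N)=O)c1` differs from compound 2 by methoxy in place of iodo on an aromatic carbon, with methoxy in place of iodo on an aromatic carbon. Among the compounds with values here, the one measured step bearing on this change is a 7.4-fold lower number from compound 1 to compound 2 (0.87 log units; beyond the scatter), with iodo in place of chloro on an aromatic carbon. Within the data shown here, no measured compound carries methoxy, so the data offer only a rough guide. A rise in the number is expected, approaching compound 1 at 4650 nM without a clear move past it. The expected size of the change is a 4.8-fold higher number from compound 2 to compound 3 (0.68 log units; beyond the scatter) in this assay. Compound 3 is estimated at 3000 nM, within an expected range from 1000 nM to 9000 nM.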

Compound 3, concentration for 50% growth inhibition: 592 nM
Beside the measured number, compound 3's estimate is 5.1-fold (0.70 log units) above it, and the stated range ends above it.
By their numbers in this assay, from the lowest: compounds 3 and 2 (each within the scatter of the next); then compound 1.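

In this assay, replacing iodo with methoxy gives a 1.1-fold lower number from compound 2 to compound 3 (0.03 log units; within the scatter) and so no change beyond the scatter, which shows that a halogen is not needed at this carbon, para to a large group, to reach the lower numbers. Methoxy in place of chloro gives a 7.9-fold lower number from compound 1 to compound 3 (0.90 log units; beyond the scatter) and leaves compound 1 alone at the higher end of the three. Nothing shown explains why methoxy and iodo match here. On these data alone, whether an amine, a carboxylic acid or a longer chain such as butoxy at this carbon would keep the number near those of compound 2 and compound 3 remains open.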